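Shifting the trifluoromethyl from compound 1 to compound 3

A few compounds are considered here, and "the series" means these few. Any claim that something is new, unique, unknown or untested is made for them only; others in the source may bear on it.

compound 1 `FC(F)(F)c1ccc(CSc2nc(Nc3ccccc3C(F)(F)F)c3ccccc3n2)cc1`: > 50000 nM
compound 2 `FC(F)(F)c1ccc(CSc2nc(Nc3ccccc3Cl)c3ccccc3n2)cc1`: > 50000 nM

In a functional assay on MDA-MB-231 cells (Homo sapiens) for cytotoxicity, read by MTT assay, with a stated time of 72 h (on this read-out higher numbers stand for weaker inhibition and lower numbers for stronger inhibition), compound 1 gives > 50000 nM, which is a limit of the assay and not a number. Compound 2 in this assay gives > 50000 nM, again a limit and not a number. Both values sit at the limit of > 50000 nM in this assay, at which 2 of the 2 values shown sit. Among the compounds with values here, the one measured comparison, a step that the two limits leave unreadable from compound 1 to compound 2, therefore cannot be sized, and the evidence gives no direction for any change on the ring that carries the amino nitrogen.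

Compound 3 `FC(F)(F)c1ccc(CSc2nc(Nc3ccc(C(F)(F)F)cc3)c3ccccc3n2)cc1` differs from compound 1 by 4-(trifluoromethyl)phenyl in place of 2-(trifluoromethyl)phenyl on a nitrogen on an aromatic ring. Within the data shown here, no measured step bears on this change, since the only comparison in hand, that of chloro for trifluoromethyl, is itself unreadable. With compound 1 at a limit and nothing to read from compound 2, the expectation for compound 3 in this assay is another limit rather than a number, with no step beyond the scatter to be predicted in either direction. Compound 3 is therefore expected at 60000 nM, with a range from 15000 nM to 250000 nM. The step this estimate implies, a step that the limit leaves unreadable from compound 1 to compound 3, is expected to stay within the scatter.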

Compound 3, half-maximal inhibitory concentration: 5460 nM
Compound 3: middle estimate off by 11-fold (1.04 log units), on the high side; measured number below the stated range.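

In this assay, the substituent on the nitrogen on an aromatic ring now has a readable direction: 4-(trifluoromethyl)phenyl in place of 2-(trifluoromethyl)phenyl gives an at least 9.1-fold lower number from compound 1 to compound 3 (0.96 log units; beyond the scatter). The two groups hold the same atoms, joined differently, so this step comes with no change in the atoms present, only in where the trifluoromethyl sits on the phenyl ring. The same group in place of 2-chlorophenyl gives an at least 9.1-fold lower number from compound 2 to compound 3 (0.96 log units; beyond the scatter), which leaves compound 3 as the only compound shown with a number, while the other two remain at a limit: the limit of > 50000 nM in this assay, at which 2 of the 3 values shown sit.

On these data alone, both steps are bounds, so the full size of the gain stays open, as does whether the trifluoromethyl of compound 3 matters at all, which an unsubstituted phenyl, or a chloro or nitrile in its place, would begin to show. Nothing shown bears on 3-(trifluoromethyl)phenyl on the same nitrogen, or on any change to the 4-(trifluoromethyl)benzyl group on the sulfur, such as a carboxylic acid on that ring.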